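Swapping an Indole for a Trihydroxyphenyl Ring

The source may hold more compounds than are shown below. What is called first, only, known or untested is meant among the compounds shown, and "the series" means these compounds.

Compound 1 `Cc1ccc(CS(=O)(=O)/C(=C/c2c[nH]c3ccccc23)C(=O)c2ccc(Cl)cc2)cc1` was tested in a functional assay on DU-145 cells (Homo sapiens) for inhibition, read by trypan blue exclusion, with a stated time of 96 h (on this read-out higher numbers stand for weaker inhibition of growth and lower numbers for stronger inhibition of growth), and in that test compound 1 gives 25000 nM. That is the highest of the three numbers measured so far, so of these compounds it shows the weakest inhibition of growth. Its nearest neighbour on the numbers is compound 3 `O=C(/C(=C\c1c[nH]c2ccc(Br)cc12)SCc1ccc(Cl)cc1Cl)c1ccc(Cl)cc1`, which in this assay gives 10000 nM, a lower number that lies beyond the scatter. Furthest away is compound 2 `O=C(/C(=C\c1ccc(F)cc1C(F)(F)F)S(=O)(=O)Cc1ccc(Cl)c(Cl)c1)c1ccc(Cl)cc1`, which in this assay gives 1000 nM, the lowest number of the three and again beyond the scatter from compound 1. Compounds 2 and 3 differ from compound 1 in more than one place, so no single change can be read off from them.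

Compound 4 `Cc1ccc(CS(=O)(=O)/C(=C/c2c(O)cc(O)cc2O)C(=O)c2ccc(Cl)cc2)cc1` has not yet been measured. It differs from compound 1 in one place: 2,4,6-trihydroxyphenyl in place of 1H-indol-3-yl on a double-bonded chain carbon bound to a double-bonded chain carbon. For the measured compounds named here, no measured pair shows this exact change, so its effect is not known from the data. For compound 4 the step of a 1.7-fold lower number from compound 1 to compound 4 (0.22 log units; within the scatter) is expected to be modest and toward stronger inhibition, though it could equally fall within the scatter. Compound 4 is therefore estimated at 15000 nM, with a likely range from 3000 nM to 60000 nM.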

Compound 4, concentration for 50% growth inhibition: > 100000 nM
Compound 4 ended at the assay's limit (the forecaster's own chance of this, stated with the estimate: 20%); middle value at least 6.6-fold (0.82 log units) away from the limit.
By their numbers in this assay, from the lowest: compound 2; then compound 3; then compound 1. At a limit, above all of these: compound 4.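

For the compounds shown here, this is the first change in the set that can be read at a single place, and swapping 1H-indol-3-yl for 2,4,6-trihydroxyphenyl gives an at least 4.0-fold higher number from compound 1 to compound 4 (0.60 log units; beyond the scatter). Going by these compounds alone, compound 1 already had the highest number of the earlier compounds, yet this swap moves further toward weaker inhibition of growth, so what sits on this double-bonded chain carbon clearly matters, and in this pair 1H-indol-3-yl is the better of the two groups. The value of compound 4 is a limit of the assay and not a number, so the step can be read only as a minimum: the limit of > 100000 nM in this assay, at which 1 of the 4 values shown sits.

The swap removes the two-ring indole and brings in the hydroxyl groups in one move, so this pair cannot tell whether the loss of the indole, the arrival of the hydroxyl groups, or both lie behind the weaker result. A plain phenyl ring or a methoxyphenyl ring at this place would separate those two parts of the change, and the compounds shown say nothing yet about how either would behave.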